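Amino(ethylsulfanyl)methyl replacing hydroxyethylamino on a shared core

This account rests on a few compounds, and the source may have more. Where it says the series, first, only, none or still open, it means among the compounds named here.

Compound 1 `Nc1nn2c(O)cc(-c3ccc(F)cc3)nc2c1[N+](=O)[O-]` and compound 2 `Nc1nn2c(O)cc(CNNCCO)nc2c1[N+](=O)[O-]` share one core. In a functional assay on K562 cells (Homo sapiens) for inhibition (a lower number here means a stronger inhibitor of growth, a higher number a weaker inhibitor of growth), compound 1 gives only a limit, > 50 ug/mL. In this assay compound 2 also gives only a limit, > 50 ug/mL. The step that the two limits leave unreadable from compound 1 to compound 2 is therefore unreadable, both values sitting at the limit of > 50 ug/mL in this assay, at which 2 of the 2 values shown sit. Compound 3 `CCSC(N)NCc1cc(O)n2nc(N)c([N+](=O)[O-])c2n1` differs from compound 2 by amino(ethylsulfanyl)methyl in place of (2-hydroxyethyl)amino on an amine nitrogen. Among the compounds with values here, no measured step bears on this change, and compound 2 stands only at a limit. The step of a number no higher from compound 2 to compound 3 (the limit leaves the size open) is expected to be nothing readable beyond the scatter. Compound 3 is expected to give 50 ug/mL, with a range from 15 ug/mL to 100 ug/mL.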

Compound 3, concentration for 50% growth inhibition: > 50 ug/mL
Compound 3: only a limit was reported; the forecaster's own chance of this, stated with the estimate: 70%; the middle value sits exactly at the limit.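

In this assay, within the data shown here, compound 1, compound 2 and compound 3 all give only limits, so no step among them can be read: the limit of > 50 ug/mL in this assay, at which 3 of the 3 values shown sit. The compounds shown leave open how strongly any of them inhibits growth, and whether either replacement changes it.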